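Lactone series: sterol O-acyltransferase 1 inhibition, compound 4

The source may report more compounds than this note shows. Statements on the series, on what has been measured and on what is new or still open speak of the compounds shown alone.

Measured in an assay on microsomes from liver for inhibition of sterol O-acyltransferase 1 (Rattus norvegicus); on this read-out higher numbers stand for weaker inhibition and lower numbers for stronger inhibition:
compound 1 `C[C@@]1(O)CC(=O)OC(CSc2nc(-c3ccccc3)c(-c3ccccc3)[nH]2)C1`: 170 nM
compound 2 `COc1ccc(-c2nc(SCC3C[C@@](C)(O)CC(=O)O3)[nH]c2-c2ccc(OC)cc2)cc1`: 340 nM
compound 3 `CC(O)(CC(=O)OC(C)(C)C)CC(O)CSc1nc(-c2ccc(Cl)cc2)c(-c2ccc(Cl)cc2)[nH]1`: 250 nM

Compound 1 holds the lowest number of the three, yet its gaps to compound 3 and to compound 2 both fall within the scatter, so the three are not separated in this assay.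

Compound 4 `CC1(C)CC(=O)OC(CSc2nc(-c3ccccc3)c(-c3ccccc3)[nH]2)C1` differs from compound 1 by a group of 9 heavy atoms (7 carbon, 2 oxygen; one six-membered non-aromatic ring with 1 hetero atom) in place of a group of 9 heavy atoms (6 carbon, 3 oxygen; one six-membered non-aromatic ring with 1 hetero atom), on a saturated chain carbon bound to a sulfur. Among the compounds with values here, no measured pair isolates this change: compound 1 and compound 3 both carry the hydroxyl, and no hydroxyl-free partner has been run. The expected step of a 1.5-fold higher number from compound 1 to compound 4 (0.17 log units; within the scatter) is therefore none beyond the scatter, with a weakening direction only slightly more likely than a strengthening one. Compound 4 is estimated at 250 nM, within 80 nM to 800 nM.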

Compound 4, half-maximal inhibitory concentration: 100 nM
The estimate for compound 4 lay 2.5-fold (0.40 log units) above the measured number, within the range that was stated.
By their numbers in this assay, from the lowest: compounds 4, 1, 3 and 2 (each within the scatter of the next, the first and the last beyond it).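

In this assay, within the data shown here, this pair gives the first direct reading of the change, with a 1.7-fold lower number from compound 1 to compound 4 (0.23 log units; within the scatter). The hydroxyl-bearing group of compound 1 can therefore give way to the hydroxyl-free group of compound 4, on the saturated chain carbon bound to a sulfur, without a shift beyond the scatter. No supporting measurement bears on this result.

Going by these compounds, whether the same exchange holds on the core of compound 2 remains open. So does the outcome of carrying an amine or a carboxylic acid in place of the hydroxyl.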